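The compounds below may be only part of what the source reports. "The series", "measured", "known", "first", "only" and "open" are said of these compounds alone.

Measured so far in a functional assay on MCF7 cells (Homo sapiens) for cytotoxicity, read by sulforhodamine B assay, with a stated time of 48 h; on this read-out lower numbers stand for stronger inhibition of growth and higher numbers for weaker inhibition of growth:

compound 1 `Cc1ccc(-c2ccc(C)n2-c2ccc(-c3nc4ccc(F)cc4s3)cc2)cc1`, 2150 nM
compound 2 `COc1ccc2nc(-c3ccc(-n4c(C)ccc4-c4ccc(C)cc4)cc3)sc2c1`, 2570 nM
compound 3 `COc1cc2nc(-c3ccc(-n4c(C)ccc4-c4ccc(F)cc4)cc3)sc2c(OC)c1OC`, 2670 nM

Compound 2 differs from compound 1 by one change, (methoxy in place of fluoro on an aromatic carbon), and in this assay this change gave a 1.2-fold higher number from compound 1 to compound 2 (0.08 log units; within the scatter). Compound 3 and compound 1 differ in more than one place, and the difference between the two cores is not broken down here; their values in this assay lie within the usual scatter of each other.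

Compound 4 `COc1ccc(-c2ccc(C)n2-c2ccc(-c3nc4cc(OC)c(OC)c(OC)c4s3)cc2)cc1` has not yet been measured. It differs from compound 3 by methoxy in place of fluoro on an aromatic carbon. Among the compounds with values here, this is the same kind of change as the one from compound 1 to compound 2, but not the same: from compound 1 to compound 2 the change sits on a ring that is part of a fused or bridged system of two rings, meta to a fused ring and para to a fused ring, whereas from compound 3 to compound 4 it sits on a six-membered aromatic ring of carbon only, para to a large group.

The step from compound 3 to compound 4 in this assay is expected to be a 1.1-fold higher number from compound 3 to compound 4 (0.04 log units; within the scatter), which rests on the earlier step of a 1.2-fold higher number from compound 1 to compound 2 (0.08 log units; within the scatter) having stayed within the scatter. Compound 4 is therefore estimated at 2900 nM, with a likely range from 1400 nM to 6000 nM.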

Compound 4, concentration for 50% growth inhibition: 1230 nM
Estimate against measurement, compound 4: 2.4-fold (0.37 log units) above; measured number outside the range, below it.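

In this assay, putting methoxy in place of fluoro, here 4-fluorophenyl to 4-methoxyphenyl, gave a 2.2-fold lower number from compound 3 to compound 4 (0.34 log units; beyond the scatter), a modest step that on its own lies beyond the usual scatter. Set beside the earlier step, which went the other way in number but stayed within the scatter, the two still cannot be told apart: the same change on two cores in this assay, a 1.2-fold higher number (0.08 log units; within the scatter) from compound 1 to compound 2 and a 2.2-fold lower number (0.34 log units; beyond the scatter) from compound 3 to compound 4, 2.6-fold (0.41 log units) apart, within the scatter of two such steps This does not show that the change acts differently on the two cores, and it does not prove that the change carries over unaltered either, for each core offers a single pair and the change sits in a different place in each.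

The compounds shown leave open how other groups at the same place would compare, such as a hydroxyl, an amine, a carboxylic acid or a longer chain like butoxy. They also leave open whether the step from compound 3 to compound 4 would recur on further cores carrying 4-fluorophenyl and 4-methoxyphenyl.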